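The source may report more compounds than this note shows. Statements on the series, on what has been measured and on what is new or still open speak of the compounds shown alone.

Measured in an ADME assay on MRC5 cells (Homo sapiens) for cytotoxicity, read by fluorescence and resazurin assay, with a stated time of 3 days; on this read-out lower numbers stand for stronger inhibition and higher numbers for weaker inhibition:
compound 1 `Cc1cn(C2CCN(Cc3cccc(Oc4ccc(Cl)cc4)c3)CC2)c(=O)[nH]c1=O` gives 25100 nM
compound 2 `Cc1cn(C2CCN(Cc3cccc(Oc4cc(Cl)cc(Cl)c4)c3)CC2)c(=O)[nH]c1=O` gives 6730 nM

Compound 2 stands lowest of the two numbers at 6730 nM. Compound 3 `Cc1cccc(Oc2cccc(CN3CCC(n4cc(C)c(=O)[nH]c4=O)CC3)c2)c1` carries 3-methylphenyl in place of 3,5-dichlorophenyl on an oxygen on an aromatic ring. For the measured compounds named here, only one measured step bears on this change: a 3.7-fold lower number from compound 1 to compound 2 (0.57 log units; beyond the scatter), a modest step with 3,5-dichlorophenyl in place of 4-chlorophenyl at the same place. Going by the values given here, no measured compound carries 3-methylphenyl, so that step is only a loose guide. Among the compounds with values here, compound 3 gives up the 3,5-dichlorophenyl group, so a modest move towards higher numbers in this assay is expected, no larger than the step seen from compound 1. The expected step is a 2.1-fold higher number from compound 2 to compound 3 (0.32 log units; beyond the scatter). For compound 3 the estimated value is 14000 nM, with an expected range from 6000 nM to 33000 nM.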

Compound 3, half-maximal inhibitory concentration: > 64000 nM
Compound 3: only a limit was reported (the forecaster's own chance of this, stated with the estimate: 10%); middle value at least 4.5-fold (0.66 log units) from the limit.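

In this assay the reading for compound 3 is a limit and not a number: the limit of > 64000 nM in this assay, at which 1 of the 3 values shown sits.

Putting 3-methylphenyl in place of 3,5-dichlorophenyl on an oxygen on an aromatic ring gives an at least 9.5-fold higher number from compound 2 to compound 3 (0.97 log units; beyond the scatter), and putting it in place of 4-chlorophenyl gives an at least 2.5-fold higher number from compound 1 to compound 3 (0.40 log units; beyond the scatter). Among these three compounds, the two groups carrying chlorine give the lower numbers and the group carrying methyl gives the highest reading, so this place spans a wider range on this read-out than the earlier step alone showed.

The compounds shown leave open whether the loss of chlorine or the arrival of methyl accounts for the move. A plain phenyl, a fluorophenyl or a phenyl carrying an amine at this place would help to separate the two.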